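The compounds below may be only part of what the source reports. "The series", "measured", "known", "first", "only" and "open" are said of these compounds alone.

Compound 3 `CCc1cc(C(C)=O)c(O)cc1OCCCCCCS(C)(=O)=O` stands at the top of the three measured compounds: in an assay on isolated protein for binding affinity to leukotriene B4 receptor 1 (Homo sapiens), tested at 1 uM (on this read-out higher numbers stand for more inhibition at the one concentration tested (going by the name of the read-out) and lower numbers for less inhibition), compound 3 gives 62%, while compound 1 `CCc1cc(C(C)=O)c(O)cc1OCCCCCCCC(C)(C)C#N` gives 29% and compound 2 `CCc1cc(C(C)=O)c(O)cc1OCCCCCCSC` gives 14%. Both steps toward it, a number 33 percentage points higher from compound 1 to compound 3 (beyond the scatter) and a number 48 percentage points higher from compound 2 to compound 3 (beyond the scatter), lie beyond the scatter. Compound 4 `CCc1cc(C(C)=O)c(O)cc1OCCCCCCC(=O)N(C)C` differs from compound 3 in one place: dimethylcarbamoyl in place of methylsulfonyl on a saturated chain carbon, six bonds along the chain from an oxygen on an aromatic ring. Within the data shown here, no measured step exchanges methylsulfonyl for dimethylcarbamoyl, so the bearing of the known steps is indirect; what they show is that both other groups at this chain position gave lower readings than methylsulfonyl. A drop beyond the scatter is therefore expected, of about a number 22 percentage points lower from compound 3 to compound 4 (beyond the scatter). Compound 4 is estimated at 40%, within 15% to 65%.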

Compound 4, a percentage reported as inhibition, at one concentration (the size of the read-out at that concentration, not a potency): 61%
Estimate against measurement, compound 4: 21 percentage points below, and the stated range covers the measured number.
By their numbers in this assay, from the lowest: compound 2; then compound 1; then compounds 4 and 3 (each within the scatter of the next).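

In this assay, dimethylcarbamoyl at this chain position keeps the reading methylsulfonyl gave, with a number 1 percentage points lower from compound 3 to compound 4 (within the scatter). Methylsulfonyl is thus not alone at this level: dimethylcarbamoyl also stands well clear of the other two groups, with a number 47 percentage points higher from compound 2 to compound 4 (beyond the scatter) and a number 32 percentage points higher from compound 1 to compound 4 (beyond the scatter). Nothing available explains why these two groups match.

As far as these compounds go, whether a carboxylic acid or an amine at this chain position would also reach this level remains open. So does whether a shorter or longer chain carrying dimethylcarbamoyl or methylsulfonyl would keep it.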